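Methyl for hydrogen on an aromatic oxygen: two cores

This account rests on a few compounds, and the source may have more. Where it says the series, first, only, none or still open, it means among the compounds named here.

Measured compounds:
compound 1 `Cn1nnnc1SCC(=O)N/N=C/c1ccc(O)cc1`: 632000 nM
compound 2 `COc1ccc(/C=N/NC(=O)CSc2nnnn2C)cc1`: > 10000000 nM (a limit)
compound 3 `Cn1nnnc1SCC(=O)N/N=C/c1ccccc1O`: > 10000000 nM (a limit)

In an ADME assay on NIH3T3 cells (Mus musculus) for cytotoxicity, read by XTT assay, with a stated time of 24 h (on this read-out higher numbers stand for weaker inhibition and lower numbers for stronger inhibition), compound 1 gives 632000 nM. Compound 2 reaches only a limit of the assay, > 10000000 nM. Compound 3 likewise sits at a limit, > 10000000 nM. The change from compound 1 to compound 2 is methyl in place of hydrogen on an oxygen on an aromatic ring; it produces an at least 15-fold higher number from compound 1 to compound 2 (1.19 log units; beyond the scatter), with compound 2 resting at the limit of > 10000000 nM in this assay, at which 2 of the 3 values shown sit. Compound 1 and compound 3 hold the same atoms joined differently; the difference between the two cores is not broken down here.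

Compound 4 `COc1ccccc1/C=N/NC(=O)CSc1nnnn1C` is not yet measured. It differs from compound 3 by methyl in place of hydrogen on an oxygen on an aromatic ring, the same change as from compound 1 to compound 2, the two place descriptions agreeing word for word. Compound 3 already stands at a limit, > 10000000 nM. The expected step is therefore small, a step that the limit leaves unreadable from compound 3 to compound 4, resting on that limit of compound 3 and on the earlier outcome an at least 15-fold higher number from compound 1 to compound 2 (1.19 log units; beyond the scatter). Compound 4 is expected to give 15000000 nM in this assay, estimated within 4000000 nM to 60000000 nM, most likely again reported only as a limit.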

Compound 4, half-maximal inhibitory concentration: 3160000 nM
For compound 4 the middle estimate is 4.7-fold (0.68 log units) above the measured one; the measured number lies below the stated range.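

Methyl in place of hydrogen on an oxygen on an aromatic ring gives, in this assay, an at least 3.1-fold lower number from compound 3 to compound 4 (0.50 log units; beyond the scatter), so the direction of the earlier step is not kept when the change is carried to the other core: the same change on two cores in this assay, an at least 15-fold higher number (1.19 log units; beyond the scatter) from compound 1 to compound 2 and an at least 3.1-fold lower number (0.50 log units; beyond the scatter) from compound 3 to compound 4, at least 50-fold (1.69 log units) apart, beyond the scatter of two such steps
Each of the two steps has one end at a limit, which makes both of them bounds and not exact sizes: the limit of > 10000000 nM in this assay, at which 2 of the 4 values shown sit.
The result rests on two pairs only; it shows that the outcome of hydroxy to methoxy on one of these cores did not predict the outcome on the other, but it gives no rule for further cores and no reason for the difference.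

The compounds shown leave open how a longer chain on the same oxygen, such as ethoxy, or an amine in place of the hydroxy, would read in this assay. They also leave open whether the opposite directions of the two steps would recur on any further core.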